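A few compounds are considered here, and "the series" means these few. Any claim that something is new, unique, unknown or untested is made for them only; others in the source may bear on it.

In an ADME assay on MRC5 cells (Homo sapiens) for inhibition, with a stated time of 72 h (a higher number here means that more compound is needed for the effect, a lower number that less compound is needed), compound 1 `COc1cccc(OC)c1C(=O)Nc1c[nH]nc1C(=O)NCc1ccccn1` gives > 50000 nM, which is a limit and not a number. Compound 3 `COc1cccc(OC)c1C(=O)Nc1c[nH]nc1C(=O)NCc1ncccc1C` gives > 50000 nM, also only a limit. Within the data shown here, compound 2 `COc1cccc(OC)c1C(=O)Nc1c[nH]nc1C(=O)NC1CCCCCC1` gives 42000 nM, the one true number so far. Compound 4 `COC(=O)c1n[nH]cc1NC(=O)c1c(OC)cccc1OC` keeps the shared core of compound 3 and has methoxy in place of ((3-methylpyridin-2-yl)methyl)amino on a carbonyl carbon.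

The closest guides are two swaps of the group on the amide nitrogen. They gave an at least 1.1-fold lower number from compound 1 to compound 2 (0.07 log units; that floor lies within the scatter) and an at least 1.1-fold higher number from compound 2 to compound 3 (0.07 log units; that floor lies within the scatter). The methyl swap gave a step that the two limits leave unreadable from compound 1 to compound 3. Neither readable step exceeds the scatter, so no clear shift in either direction is expected.

The expected step is an at least 1.1-fold lower number from compound 3 to compound 4 (0.04 log units; that floor lies within the scatter).

Compound 4 is estimated at 45000 nM, with an expected range from 22000 nM to 90000 nM.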

Compound 4, half-maximal effective concentration: > 50000 nM
Compound 4: no number, only a limit; the forecaster's own chance of this, stated with the estimate: 60%; middle value at least 1.1-fold (0.04 log units) away from the limit.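

Swapping ((3-methylpyridin-2-yl)methyl)amino for methoxy on this carbonyl carbon removes the ring and most of the group, yet in this assay compound 4 gives > 50000 nM, which is a limit and not a number. Measured against the cycloheptylamino group, methoxy gives an at least 1.1-fold higher number from compound 2 to compound 4 (0.07 log units; that floor lies within the scatter), so no real shift is shown. The steps to compound 4 from compound 1 and compound 3 cannot be read, because both ends of each are limits: the limit of > 50000 nM in this assay, at which 3 of the 4 values shown sit.

Going by these compounds, whether a carboxylic acid at this carbonyl carbon would give a true number in this assay remains open.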